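A 4-Cyanophenyl Group in Place of Methoxymethyl

The source may report more compounds than this note shows. Statements on the series, on what has been measured and on what is new or still open speak of the compounds shown alone.

Three compounds that share one core and differ only in the group on a carbonyl carbon have been measured in an ADME assay on microsomes from liver (Mus musculus) for pharmacokinetics; on this read-out higher numbers stand for fast clearance and lower numbers for slow clearance. Compound 1 (`C[C@H](NC(=O)CC(F)(F)F)c1ccc(NC(=O)[C@H]2C[C@@H]2c2cccnc2)cc1`) gives 83.7 mL.min-1.g-1, compound 2 (`COCC(=O)N[C@@H](C)c1ccc(NC(=O)[C@H]2C[C@@H]2c2cccnc2)cc1`) gives 43.2 mL.min-1.g-1, and compound 3 (`C[C@H](NC(=O)c1ccc(F)cc1)c1ccc(NC(=O)[C@H]2C[C@@H]2c2cccnc2)cc1`) gives 13.7 mL.min-1.g-1. Compound 2 therefore stands with compound 1 at the fast-clearance end of this small set, and the gap between them is a 1.9-fold lower number from compound 1 to compound 2 (0.29 log units; within the scatter).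

Compound 4 (`C[C@H](NC(=O)c1ccc(C#N)cc1)c1ccc(NC(=O)[C@H]2C[C@@H]2c2cccnc2)cc1`) has not yet been measured. Reaching it from compound 2 puts 4-cyanophenyl in place of methoxymethyl on a carbonyl carbon. The closest guide is the change to 4-fluorophenyl, which also brings in a six-membered aromatic ring of carbon only. That change gave a 3.2-fold lower number from compound 2 to compound 3 (0.50 log units; beyond the scatter), and from the other chain it gave a 6.1-fold lower number from compound 1 to compound 3 (0.79 log units; beyond the scatter). Both steps are modest but beyond the scatter, and both go towards slower clearance. For the measured compounds named here, no compound with a 4-cyanophenyl group has been measured yet, so this guide is only indirect. In this assay the expected step is a 2.7-fold lower number from compound 2 to compound 4 (0.43 log units; beyond the scatter), close in size to the 4-fluorophenyl change. For compound 4 the estimated value is 16 mL.min-1.g-1, with an expected range from 7 mL.min-1.g-1 to 36 mL.min-1.g-1.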

Compound 4, intrinsic clearance in microsomes: 53 mL.min-1.g-1
Estimate against measurement, compound 4: 3.3-fold (0.52 log units) below; measured number above the stated range.
By their numbers in this assay, from the lowest: compound 3; then compounds 2, 4 and 1 (each within the scatter of the next).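

In this assay, an aromatic ring of carbon only on this carbonyl carbon does not on its own bring slow clearance: putting 4-cyanophenyl in place of methoxymethyl gives a 1.2-fold higher number from compound 2 to compound 4 (0.09 log units; within the scatter) and leaves compound 4 level with compound 2, and putting it in place of 2,2,2-trifluoroethyl gives a 1.6-fold lower number from compound 1 to compound 4 (0.20 log units; within the scatter) and leaves it level with compound 1 as well. The low number of compound 3 therefore goes with the 4-fluorophenyl group in particular and not with aromatic rings on this carbonyl carbon in general, as cyano in place of fluoro on an aromatic carbon gives a 3.9-fold higher number from compound 3 to compound 4 (0.59 log units; beyond the scatter) even though the rest of the molecule stays the same. The data shown offer no explanation for this difference between the two ring groups.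

The compounds shown leave open whether a ring carrying chloro, methoxy or no group at all in place of the cyano would stand with compound 3 or with compound 4. They also leave open how an amine or a carboxylic acid on that ring would fare in this assay on the same shared core.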